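Ortho-halogen swap on the triazole benzyl arm, second core

This account rests on a few compounds, and the source may have more. Where it says the series, first, only, none or still open, it means among the compounds named here.

Measured compounds:
compound 1, `O=C1/C(=C/c2ccccc2F)CN(Cc2cn(Cc3ccccc3F)nn2)C/C1=C\c1ccccc1F`, 6500 nM
compound 2, `O=C1/C(=C/c2ccccc2F)CN(Cc2cn(Cc3ccccc3Cl)nn2)C/C1=C\c1ccccc1F`, 5300 nM
compound 3, `Cc1ccc(/C=C2\CN(Cc3cn(Cc4ccccc4F)nn3)C/C(=C\c3ccc(C)cc3)C2=O)cc1`, 18000 nM

All three numbers come from a functional assay on 4T1 cells (Mus musculus) for cytotoxicity, read by MTT assay, with a stated time of 24 h; a lower number here means a stronger inhibitor, a higher number a weaker inhibitor. Compound 1 and compound 2 share one core and differ only at the benzyl ring on the triazole: chloro in place of fluoro on an aromatic carbon. The step this made is a 1.2-fold lower number from compound 1 to compound 2 (0.09 log units; within the scatter), so the two values cannot be separated here.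

Compound 3 carries a different core; the difference between the two cores is not broken down here. In this assay compound 3 gives 18000 nM, the highest of the three numbers and beyond the scatter from both compound 1 and compound 2.

Compound 4, `Cc1ccc(/C=C2\CN(Cc3cn(Cc4ccccc4Cl)nn3)C/C(=C\c3ccc(C)cc3)C2=O)cc1`, has not been measured. It stands to compound 3 as compound 2 stands to compound 1: chloro in place of fluoro on an aromatic carbon. The place lines of the two changes read the same word for word, so this is the same change made once more, now on the core of compound 3.

The step from compound 3 to compound 4 is expected to be small, a 1.2-fold lower number from compound 3 to compound 4 (0.08 log units; within the scatter), because the same change gave a 1.2-fold lower number from compound 1 to compound 2 (0.09 log units; within the scatter) and nothing else in the series speaks for a larger effect on this core. Compound 4 is therefore estimated at 15000 nM, with a range of 7000 nM to 35000 nM.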

Compound 4, half-maximal inhibitory concentration: 23200 nM
The estimate for compound 4 lay 1.5-fold (0.19 log units) below the measured number; the measured number falls inside the stated range.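

In this assay, chloro in place of fluoro on an aromatic carbon gives a 1.3-fold higher number from compound 3 to compound 4 (0.11 log units; within the scatter), and compound 3 and compound 4 cannot be separated on this read-out. The steps on the two cores do not differ from each other: the same change on two cores in this assay, a 1.2-fold lower number (0.09 log units; within the scatter) from compound 1 to compound 2 and a 1.3-fold higher number (0.11 log units; within the scatter) from compound 3 to compound 4, 1.6-fold (0.20 log units) apart, within the scatter of two such steps. This shows that, in both pairs, the swap from 2-fluorobenzyl to 2-chlorobenzyl leaves the two compounds inseparable, but it does not show that a real effect carries from one core to the other, as neither step stands clear of the scatter, and one pair on each of two cores says nothing about further cores or about other changes at this place.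

The compounds shown leave open whether any other group on this aromatic carbon, such as a methoxy, a trifluoromethyl, a nitrile, an amine or a carboxylic acid, would give a step beyond the scatter on either core. Also open, from the compounds shown here alone, is what a longer chain in place of the benzyl link to the triazole would do, and whether such a change would read the same on the core of compound 1 and the core of compound 3.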